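Replacing the methoxy of compound 2 with fluoro

This account rests on a few compounds, and the source may have more. Where it says the series, first, only, none or still open, it means among the compounds named here.

The series shares one core, carried in compound 2 `COc1ccc(-c2nnc(Nc3ncccn3)o2)cc1`. In a functional assay, with a stated time of 30 min, tested at 20 uM (a higher number here means more inhibition at the concentration tested (going by the name of the read-out), a lower number less inhibition), compound 2 gives 45.8%, the lowest of the two numbers available. Compound 3 `COc1ccc(-c2nnc(Nc3ncccn3)o2)cc1OC`, the nearest, gives 49.5% in this assay, and the step of a number 3.7 percentage points higher from compound 2 to compound 3 (within the scatter), methoxy in place of hydrogen on an aromatic carbon, lies within the scatter. Compound 1 `Cc1ccc(-c2nnc(Nc3ncccn3)o2)cc1` reaches only the limit of < 20% in this assay. The step of a number at least 25.8 percentage points higher from compound 1 to compound 2 (beyond the scatter), methoxy in place of methyl on an aromatic carbon, is beyond the scatter and its size rests on (the limit of < 20% in this assay, at which 1 of the 3 values shown sits).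

Compound 4 `Fc1ccc(-c2nnc(Nc3ncccn3)o2)cc1` is not yet measured. It differs from compound 2 by fluoro in place of methoxy on an aromatic carbon. Within the data shown here, no measured step swaps methoxy for fluoro. The step from compound 1 to compound 2 is the one that bears on it: with methyl in place of methoxy, compound 1 sat at the limit. Compound 4 also lacks the methoxy of compound 2, so a drop is expected, of a size near the one seen, though compound 3 shows that a second methoxy did not move the number beyond the scatter. For compound 4 the expected step is a number 20.8 percentage points lower from compound 2 to compound 4 (beyond the scatter). Compound 4 is therefore estimated at 25%, with a range from 10% to 42% in this assay.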

Compound 4, a percentage reported as inhibition, at one concentration (the size of the read-out at that concentration, not a potency): 41.9%
Compound 4: the middle estimate sits 16.9 percentage points below what was measured; the measured number falls inside the stated range.
By their numbers in this assay, from the lowest: compounds 4, 2 and 3 (each within the scatter of the next). At a limit, below all of these: compound 1.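

In this assay, fluoro in place of methoxy on an aromatic carbon para to a large group gives a number 3.9 percentage points lower from compound 2 to compound 4 (within the scatter), so at this position the methoxy of compound 2 is not required to keep the number, and a single fluorine, with no hydrogen-bond acceptor, serves within the scatter. The low reading of compound 1 therefore does not extend to every replacement of methoxy, since fluoro in place of methyl gives a number at least 21.9 percentage points higher from compound 1 to compound 4 (beyond the scatter), and among the groups shown at this position only methyl goes with the low reading. The size of that step rests on compound 1, whose value is a limit and not a number: the limit of < 20% in this assay, at which 1 of the 4 values shown sits.

Still open, as far as these compounds go, is whether an amine, a carboxylic acid or a longer chain such as ethoxy at this position would stay with compound 2 and compound 4 or fall to the limit of compound 1. Also open, from the compounds shown here alone, is whether fluoro would hold its number alongside the second methoxy of compound 3, and each reading, taken at one concentration, gives no potency.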